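The source may report more compounds than this note shows. Statements on the series, on what has been measured and on what is new or still open speak of the compounds shown alone.

Measured compounds:
- compound 1 `CCCc1nc(C)c2c(C)nn(C)c(=O)n12` — in a functional assay for inhibition, with Homo sapiens as the target (a lower number here means a stronger inhibitor, a higher number a weaker inhibitor), only a limit: > 48000 nM
- compound 2 `C=CCn1ncc2c(C)nc(CC)n2c1=O` — in this assay only a limit: > 48000 nM
- compound 3 `CCc1nnc(O)n2c(C(C)(C)C)nc(C)c12` — in this assay: 26000 nM

Compound 1 returns no number in this assay, only a limit, and so sits at the limit of > 48000 nM in this assay, at which 2 of the 3 values shown sit. Compound 2 likewise returns only a limit there. Among the compounds with values here, compound 3 is the one member of the set with a measured value, and that value is weak. Where compound 1 stands relative to compound 3 cannot be stated as a step, since compound 1 has only a limit; the two values show only that compound 3 was resolved while compound 1 was not.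

Compound 4 `CCCc1nc(C)c2c(C)nn(CCC)c(=O)n12` differs from compound 1 by ethyl in place of hydrogen on a saturated chain carbon bound to an aromatic nitrogen; the same difference, cut one bond further out, reads methyl to propyl. Within the data shown here, no step between measured compounds is recorded for a change of this kind, so nothing sets the size of this step. With compound 1 unresolved at the limit of > 48000 nM in this assay, at which 2 of the 3 values shown sit, and compound 3 weak, the expectation is a step within the usual scatter in either direction, with a substantial chance that compound 4 also returns only a limit. The step from compound 1 to compound 4 is estimated at an at least 1.0-fold lower number from compound 1 to compound 4 (0.02 log units; that floor lies within the scatter). For compound 4 the estimate in this assay is 45000 nM, with a range from 12000 nM to 160000 nM.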

Compound 4, half-maximal inhibitory concentration: > 48000 nM
Compound 4 ended at the assay's limit (the forecaster's own chance of this, stated with the estimate: 60%); at least 1.0-fold (0.02 log units) between middle value and limit.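

In this assay compound 4 gives > 48000 nM, a limit and not a number. Compound 1 is also held only by a limit, so no step can be read between compound 1 and compound 4: the limit of > 48000 nM in this assay, at which 3 of the 4 values shown sit.

The compounds shown leave open how far ethyl in place of hydrogen on this saturated chain carbon moves the inhibition, if at all.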